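The compounds below may be only part of what the source reports. "The series", "measured", "known", "first", "only" and "open" are said of these compounds alone.

In an ADME assay on BJ cells (Homo sapiens) for cytotoxicity, read by CellTiter-Glo and resazurin assay, with a stated time of 72 h (a higher number here means that more compound is needed for the effect, a lower number that less compound is needed), compound 1 (`CCCN(Cc1ccc(OCCCCCC(=O)OCC)cc1)C(=O)c1ccc(Br)cc1`) gives only a limit, > 26000 nM, and not a number. Compound 2 (`CCCNCc1ccc(OCCCCCC(=O)OCC)cc1`) also gives only a limit, > 26000 nM, so it stands at the limit of > 26000 nM in this assay, at which 2 of the 2 values shown sit, alongside compound 1. Compound 3 (`CCOC(=O)CCCCCOc1ccc(CO)cc1`) differs from compound 2 by hydroxy in place of propylamino on a saturated chain carbon bound to an aromatic carbon. Going by the values given here, the one measured step, a step that the two limits leave unreadable from compound 1 to compound 2, is a change on an amine nitrogen and sets no size for this change, so no step beyond the scatter is expected in this assay. The expected change is a number no higher from compound 2 to compound 3 (the limit leaves the size open), with no direction foreseen. Compound 3 is estimated at 26000 nM, within an expected range of 15000 nM to 40000 nM, most likely again as a limit.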

Compound 3, half-maximal effective concentration: > 27100 nM
Compound 3: a limit, no number; the forecaster's own chance of this, stated with the estimate: 85%; middle value at least 1.0-fold (0.01 log units) away from the limit.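

Compound 3 gives > 27100 nM as a limit and not a number. Going by these compounds alone, compound 2 also gives only a limit, so no step between them can be read. The compounds shown leave open whether hydroxy in place of propylamino changes the half-maximal effective concentration.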